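The compounds below may be only part of what the source reports. "The series", "measured", "known", "first", "only" and "open" are said of these compounds alone.

Measured so far:
Compound 1 `O=C(CN1C(=O)S/C(=C/c2ccccn2)C1=O)Nc1nc2ccccc2s1`: 9300 nM
Compound 2 `O=C(COc1ccc2cc(/C=C3/SC(=O)NC3=O)ccc2c1)Nc1c(F)cc(F)cc1Br`: 1100 nM
Compound 3 `CCOc1ccc2nc(NC(=O)COc3ccc4cc(/C=C5/SC(=O)NC5=O)ccc4c3)sc2c1`: 3600 nM

In an assay on isolated protein for inhibition of histone deacetylase 4 (Homo sapiens), with a stated time of 1 h (on this read-out lower numbers stand for stronger inhibition and higher numbers for weaker inhibition), compound 2 stands lowest of the three numbers, with compound 3 the nearest and compound 1 the furthest, both beyond the usual scatter. Compound 4 `COc1ccc(NC(=O)COc2ccc3cc(/C=C4/SC(=O)NC4=O)ccc3c2)cc1` differs from compound 2 in one place: 4-methoxyphenyl in place of 2-bromo-4,6-difluorophenyl on an amide-type nitrogen. Within the data shown here, no measured pair shows this change on its own, so the size of the step it brings is not known from these data. A moderate rise in the number, in the direction of weaker inhibition and not far beyond the scatter, is expected, as the step of a 2.0-fold higher number from compound 2 to compound 4 (0.30 log units; within the scatter) means. Compound 4 is therefore estimated at 2200 nM in this assay, within a range from 700 nM to 7000 nM.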

Compound 4, half-maximal inhibitory concentration: 4700 nM
The estimate for compound 4 lay 2.1-fold (0.33 log units) below the measured number, and the stated range covers the measured number.
By their numbers in this assay, from the lowest: compound 2; then compounds 3, 4 and 1 (each within the scatter of the next, the first and the last beyond it).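

In this assay the group on the amide-type nitrogen is shown to affect the read-out: 4-methoxyphenyl in place of 2-bromo-4,6-difluorophenyl gives a 4.3-fold higher number from compound 2 to compound 4 (0.63 log units; beyond the scatter) in the direction of weaker inhibition. Among these compounds, no earlier pair gave a step at this position, and this modest step lies beyond the usual scatter. No measurement at hand explains the shift.

From the compounds shown here alone, both aryl groups differ in all their substituents at once, so which substituent carries the step remains open. An unsubstituted phenyl or a 2-bromophenyl on that nitrogen would help to separate these contributions.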